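Methyl in Place of Trifluoromethyl in a Weakly Active Series

The compounds below may be only part of what the source reports. "The series", "measured", "known", "first", "only" and "open" are said of these compounds alone.

Measured compounds:
compound 1 `O=C(O)CCCCCCC(=O)Nc1ccc(C2=C(c3ccc(O)cc3)C3CC(S(=O)(=O)Oc4ccc(C(F)(F)F)cc4)C2O3)cc1` gives 77000 nM
compound 2 `COc1ccccc1OS(=O)(=O)C1CC2OC1C(c1ccc(NC(=O)CCCCCCC(=O)NO)cc1)=C2c1ccc(O)cc1` gives 44700 nM
compound 3 `O=C(O)CCCCCCC(=O)Nc1ccc(OS(=O)(=O)C2CC3OC2C(c2ccc(O)cc2)=C3c2ccc(O)cc2)cc1` gives 34800 nM

All three compounds were tested in a functional assay on DU-145 cells (Homo sapiens) for inhibition, read by MTT assay, with a stated time of 72 h; on this read-out lower numbers stand for stronger inhibition and higher numbers for weaker inhibition. Compound 1 stands at the highest of the three numbers. The number for compound 2 lies within the usual scatter of that for compound 1, so the two cannot be told apart. Within the data shown here, compound 3 gives a lower number than compound 1, and that gap lies beyond the scatter; no step between these two is defined, since they differ in more than one place, so only the two values themselves can be compared.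

The unmeasured compound 4 `Cc1ccc(OS(=O)(=O)C2CC3OC2C(c2ccc(NC(=O)CCCCCCC(=O)O)cc2)=C3c2ccc(O)cc2)cc1` differs from compound 1 in a single place: methyl in place of trifluoromethyl on an aromatic carbon. Among the measured compounds shown here, no step between measured compounds covers this change, so there is nothing in the data to set its size or direction. With compound 1 at 77000 nM, the step from compound 1 to compound 4 is expected to be small, most likely none beyond the scatter, and is estimated as a 1.3-fold lower number from compound 1 to compound 4 (0.11 log units; within the scatter). Compound 4 is therefore estimated to give 60000 nM, with a range from 25000 nM to 150000 nM.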

Compound 4, half-maximal inhibitory concentration: 80800 nM
The estimate for compound 4 lay 1.3-fold (0.13 log units) below the measured number; low and high end bracket the measured number.
By their numbers in this assay, from the lowest: compounds 3, 2, 1 and 4 (each within the scatter of the next, the first and the last beyond it).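

In this assay, replacing trifluoromethyl with methyl on an aromatic carbon para to a large group gives a 1.0-fold higher number from compound 1 to compound 4 (0.02 log units; within the scatter) and so leaves the two compounds indistinguishable on this read-out. Among these compounds, the earlier compounds offered no step between any pair, so this is the only direct reading of a single change at this place, and it shows that going from 4-(trifluoromethyl)phenyl to 4-methylphenyl, with the group shrinking from four heavy atoms to one, produces no difference that can be read here. The data at hand hold nothing that explains this outcome.

Among the compounds shown here, the pair covers only two groups at this place, so it remains open whether an amine, a nitrile or a carboxylic acid on the same aromatic carbon would move the number beyond the scatter, and a single step cannot show whether this place is insensitive to substitution in general. Going by these compounds, it is also open whether the same exchange would read the same way in a compound carrying a different chain, such as the hydroxamic acid chain of compound 2, or a longer chain on the amide.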